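Sulfonyl side chains on the shared core of compound 1

The compounds below may be only part of what the source reports. "The series", "measured", "known", "first", "only" and "open" are said of these compounds alone.

Compound 1: `CS(=O)(=O)NNc1nonc1/C(=N/O)Nc1ccc(F)c(Br)c1` — > 800 nM
Compound 2: `O=S(=O)(CCNc1nonc1/C(=N/O)Nc1ccc(F)c(Br)c1)N1CCC1` — 143 nM
Compound 3: `C#CCNS(=O)(=O)CCNc1nonc1/C(=N/O)Nc1ccc(F)c(Br)c1` — 33 nM

In an assay on HeLa cells for inhibition of Indoleamine 2,3-dioxygenase 1 (Homo sapiens), read by spectrophotometry, with a stated time of 24 h (a higher number here means that more compound is needed for the effect, a lower number that less compound is needed), the value of compound 1 is a limit of the assay, not a number (the limit of > 800 nM in this assay, at which 1 of the 3 values shown sits). Compound 2 shows an at least 5.5-fold lower number from compound 1 to compound 2 (0.74 log units; beyond the scatter), and compound 3 shows an at least 24-fold lower number from compound 1 to compound 3 (1.38 log units; beyond the scatter), with a 4.3-fold lower number from compound 2 to compound 3 (0.64 log units; beyond the scatter) between them. Compound 4, `NS(=O)(=O)CCONc1nonc1/C(=N/O)Nc1ccc(F)c(Br)c1`, differs from compound 1 by 2-sulfamoylethoxy in place of methanesulfonamido on a nitrogen on an aromatic ring. Both measured steps that start from compound 1 replace the methanesulfonamido group with a two-carbon sulfonyl chain and give at least modest to large drops in this assay, so a lower number is expected for compound 4 as well, estimated as an at least 6.6-fold lower number from compound 1 to compound 4 (0.82 log units; beyond the scatter). For compound 4 the expected value in this assay is 120 nM, in the range 30 nM to 500 nM.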

Compound 4, half-maximal effective concentration: 27 nM
Compound 4: middle estimate off by 4.4-fold (0.65 log units), on the high side; the measured number lies below the stated range.
By their numbers in this assay, from the lowest: compounds 4 and 3 (each within the scatter of the next); then compound 2. At a limit, above all of these: compound 1.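

In this assay, 2-sulfamoylethoxy on a nitrogen on an aromatic ring gives an at least 29-fold lower number from compound 1 to compound 4 (1.47 log units; beyond the scatter). The value of compound 1 is a limit of the assay, not a number: the limit of > 800 nM in this assay, at which 1 of the 4 values shown sits. With a 1.2-fold lower number from compound 3 to compound 4 (0.09 log units; within the scatter), this chain, with its ether oxygen and free sulfamoyl end, matches 2-(propargylsulfamoyl)ethyl without any propargyl group, while a 5.3-fold lower number from compound 2 to compound 4 (0.72 log units; beyond the scatter) sets it apart from the azetidin-1-yl chain.

The compounds shown leave open whether the oxygen or the free sulfamoyl end accounts for this, since both change together in compound 4. Going by these compounds, how a longer chain or a carboxylic acid in place of the sulfamoyl group would read in this assay also remains open.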